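The compounds below may be only part of what the source reports. "The series", "measured", "known", "first", "only" and "open" are said of these compounds alone.

Working notes on the series. Compound 1 `Nc1cn(COCCO)c(=O)[nH]c1=O` and compound 2 `Cc1cc(=O)[nH]c(=O)n1COCCO` share a core and were both run in a functional assay on Vero cells (Chlorocebus sabaeus) for cytotoxicity, read by MTT assay; a higher number here means that more compound is tolerated, a lower number that less compound is tolerated. For compound 1 the reading is a limit, > 497000 nM. For compound 2 the reading is likewise a limit, > 500000 nM. For the measured compounds named here, compound 2 therefore stands where the only other value also stands, namely at the limit of > 500000 nM in this assay, at which 1 of the 2 values shown sits, with the companion reading at the limit of > 497000 nM in this assay, at which 1 of the 2 values shown sits; neither gives a number inside the tested range. Compound 3 `COC(=O)c1cc(=O)[nH]c(=O)n1COCCO` is not yet measured in this assay; it carries methoxycarbonyl in place of methyl on an aromatic carbon, (methoxycarbonyl in place of methyl on an aromatic carbon). Going by the values given here, no measured step is available to calibrate this change. Because compound 2 sits at the limit of > 500000 nM in this assay, at which 1 of the 2 values shown sits, compound 3 is expected to show no step beyond the scatter, a number no higher from compound 2 to compound 3 (the limit leaves the size open), and will most probably return a limit again. The estimate for compound 3 in this assay is 500000 nM, expected within 200000 nM to 1000000 nM.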

Compound 3, half-maximal cytotoxic concentration: > 409000 nM
Compound 3 gave a limit, no number; the forecaster's own chance of this, stated with the estimate: 85%; the middle value does not contradict the limit.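

Compound 2 and compound 3 each give only a limit in this assay, and no step can be read between them. The compounds shown leave open the concentration at which any of them becomes cytotoxic, and whether methoxycarbonyl in place of methyl on an aromatic carbon shifts it.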